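This account rests on a few compounds, and the source may have more. Where it says the series, first, only, none or still open, it means among the compounds named here.

Measured in a functional assay on MCF7 cells (Homo sapiens) for inhibition, read by CCK-8 assay, with a stated time of 48 h; on this read-out lower numbers stand for stronger inhibition and higher numbers for weaker inhibition:

Compound 1 `COc1cc(-c2ccnc3cc(-c4ccc(F)cc4)nn23)cc(OC)c1OC`: 1280 nM
Compound 2 `COc1cc(-c2ccnc3cc(-c4ccc(Cl)cc4)nn23)cc(OC)c1OC`: 2320 nM
Compound 3 `COc1ccc(-c2cc3nccc(-c4cc(OC)c(OC)c(OC)c4)n3n2)cc1`: 125 nM

Compound 2 gives the highest of the three numbers in this assay. Compound 1 sits nearest to it, with a 1.8-fold higher number from compound 1 to compound 2 (0.26 log units; within the scatter), and compound 3 lies furthest away, with a 19-fold lower number from compound 2 to compound 3 (1.27 log units; beyond the scatter). The step to compound 4 `COc1cc(-c2ccnc3cc(-c4ccc5cnn(C)c5c4)nn23)cc(OC)c1OC` replaces (1-methyl-1H-indazol-6-yl in place of 4-chlorophenyl on an aromatic carbon). Within the data shown here, no measured pair exchanges a halogen for a fused two-ring group, so the closest guidance comes from the two steps in which a methoxy takes the place of a halogen on the same aromatic carbon: a 10-fold lower number from compound 1 to compound 3 (1.01 log units; beyond the scatter) and a 19-fold lower number from compound 2 to compound 3 (1.27 log units; beyond the scatter). Both show that moving away from a halogen at that position can lower the number considerably, although neither step introduces a second ring or the two hydrogen-bond acceptors that 1-methyl-1H-indazol-6-yl carries. Compound 4 is therefore expected to show a lower number than compound 2, estimated as a 3.3-fold lower number from compound 2 to compound 4 (0.52 log units; beyond the scatter), smaller than the methoxy steps given the different kind of change. The estimate for compound 4 in this assay is 700 nM, with a range from 150 nM to 3000 nM.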

Compound 4, half-maximal inhibitory concentration: 279 nM
The estimate for compound 4 lay 2.5-fold (0.40 log units) above the measured number; measured number inside the range.
By their numbers in this assay, from the lowest: compound 3; then compound 4; then compounds 1 and 2 (each within the scatter of the next).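

In this assay, the position on the five-membered aromatic ring accepts a fused two-ring group: 1-methyl-1H-indazol-6-yl gives an 8.3-fold lower number from compound 2 to compound 4 (0.92 log units; beyond the scatter) in place of 4-chlorophenyl and a 4.6-fold lower number from compound 1 to compound 4 (0.66 log units; beyond the scatter) in place of 4-fluorophenyl, so a lower number than the halogen compounds give is not confined to the methoxy compound. The same group does not match 4-methoxyphenyl, with a 2.2-fold higher number from compound 3 to compound 4 (0.35 log units; beyond the scatter), which leaves compound 3 the lowest of the four. Nothing available here accounts for these differences.

The compounds shown leave open which part of 1-methyl-1H-indazol-6-yl matters, the methyl or the ring nitrogens, and what an ethyl in place of that methyl would do. They also leave open how a 4-aminophenyl group would compare with 4-methoxyphenyl at this position.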